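This account rests on a few compounds, and the source may have more. Where it says the series, first, only, none or still open, it means among the compounds named here.

Values in a functional assay on Maver1 cells (Homo sapiens) for inhibition, read by luminescence and CellTiter-Glo, with a stated time of 72 h; on this read-out higher numbers stand for weaker inhibition and lower numbers for stronger inhibition:
- Compound 1 `C=CC(=O)Nc1ccc(Cn2nc(-c3ccc(Oc4ccccc4)cc3)cc2C(=O)O)cc1`: > 60000 nM, which is a limit of the assay and not a number.
- Compound 2 `C=CC(=O)Nc1ccc(Cn2nc(-c3ccc(Oc4ccccc4)cc3)cc2C(=O)OCC)cc1`: 13300 nM
- Compound 3 `C=CC(=O)Nc1ccc(Cn2nc(-c3ccc(Oc4ccccc4)cc3)cc2CO)cc1`: 7000 nM

Compound 2, at 13300 nM, stands level with compound 3, as a 1.9-fold lower number from compound 2 to compound 3 (0.28 log units; within the scatter) shows. Compound 4 `CCOC(=O)c1cc(-c2ccc(Oc3ccccc3)cc2)nn1Cc1ccc(NC(=O)CCl)cc1` changes compound 2 at a different group: chloromethyl in place of vinyl on a carbonyl carbon. The measured steps, an at least 4.5-fold lower number from compound 1 to compound 2 (0.65 log units; beyond the scatter) and an at least 8.5-fold lower number from compound 1 to compound 3 (0.93 log units; beyond the scatter), exchange only carboxy, ethoxycarbonyl and hydroxymethyl, and the vinyl group stays untouched in all of them. None of them therefore measures this change, and the expectation stays close to compound 2 at 13300 nM. The expected change in this assay is a 1.7-fold lower number from compound 2 to compound 4 (0.22 log units; within the scatter), which means no step beyond the scatter. For compound 4 the estimated value is 8000 nM, with an expected range of 2500 nM to 25000 nM.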

Compound 4, half-maximal inhibitory concentration: 400 nM
Compound 4: the middle estimate sits 20-fold (1.30 log units) above what was measured; the measured number lies below the stated range.
By their numbers in this assay, from the lowest: compound 4; then compounds 3 and 2 (each within the scatter of the next). At a limit, above all of these: compound 1.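

In this assay, for the compounds shown here, the earlier steps changed only carboxy, ethoxycarbonyl and hydroxymethyl, so this is the first reading at the carbonyl carbon, and the position proves highly sensitive: a 33-fold lower number from compound 2 to compound 4 (1.52 log units; beyond the scatter). Vinyl and chloromethyl both count 2 heavy atoms and no hydrogen-bond donors or acceptors, so these counts do not separate them. Nothing measured here explains the size of this step.

On these data alone, it remains open whether chloromethyl would lower the number as much alongside hydroxymethyl or carboxy, and how a plain methyl or a bromomethyl group would behave on this carbonyl carbon.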